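Swapping trifluoromethyl for chloro on a quinazoline series

The compounds below may be only part of what the source reports. "The series", "measured", "known", "first", "only" and "open" are said of these compounds alone.

Of the compounds shown here, three sharing a bicyclic amine have been measured. Compound 1 `Cc1nc(N[C@@H]2C[C@H]3CC[C@@H]2C3)c2cc(-c3cccc(Cl)c3)ccc2n1` gives 50% in an ADME assay (Homo sapiens) for metabolic stability; a lower number here means that less of the compound is left, a higher number that more of the compound is left. Compound 2 `Cc1nc(N[C@@H]2C[C@H]3CC[C@@H]2C3)c2cc(-c3cccc(C(F)(F)F)c3)ccc2n1` gives 75% in this assay. The change chloro in place of trifluoromethyl on an aromatic carbon gave a number 25 percentage points lower from compound 2 to compound 1 (beyond the scatter). Compound 3 `FC(F)(F)c1ccc(-c2ccc3nc(Cl)nc(N[C@@H]4C[C@H]5CC[C@@H]4C5)c3c2)cc1` gives 73% in this assay; the difference between the cores of compound 3 and compound 2 is not broken down here. Compound 4 `Clc1ccc(-c2ccc3nc(Cl)nc(N[C@@H]4C[C@H]5CC[C@@H]4C5)c3c2)cc1` has not been measured; it differs from compound 3 by chloro in place of trifluoromethyl on an aromatic carbon. This is the same kind of change as from compound 2 to compound 1, but the place differs: there the chloro sits meta to a large group, here para to a large group. Among the measured compounds shown here, on the strength of the one earlier step, a number 25 percentage points lower from compound 2 to compound 1 (beyond the scatter), a step of a number 18 percentage points lower from compound 3 to compound 4 (beyond the scatter) is expected. Compound 4 is therefore estimated at 55%.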

Compound 4, percent of the compound remaining: 46%
Estimate against measurement, compound 4: 9 percentage points above; measured number inside the range.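

In this assay, chloro in place of trifluoromethyl gave a number 27 percentage points lower from compound 3 to compound 4 (beyond the scatter) on a second core. Set beside the earlier step, the size of the change carried over: the same change on two cores in this assay, a number 25 percentage points lower (beyond the scatter) from compound 2 to compound 1 and a number 27 percentage points lower (beyond the scatter) from compound 3 to compound 4, 2 percentage points apart, within the scatter of two such steps

This rests on two pairs only, which differ both in their cores and in where the group sits, so it shows neither which of these matters nor why the number falls, and it cannot be extended to other cores.

The compounds shown carry only trifluoromethyl and chloro at this place, so a nitrile or a methoxy group there remains open. The bicyclic amine is also shared throughout, leaving open how the same change would behave with an open-chain amine or a morpholine in its place.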